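Acetylating the Free Hydroxy of Compound 1

The source may hold more compounds than are shown below. What is called first, only, known or untested is meant among the compounds shown, and "the series" means these compounds.

In a functional assay on MDA-MB-231 cells (Homo sapiens) for cytotoxicity (on this read-out higher numbers stand for weaker inhibition and lower numbers for stronger inhibition), compound 1 (`COCC1=C2/C(=C\[C@@]3(C)CC[C@](O)(O3)[C@@](C)(O)C[C@@H]2O)OC1=O`) gives > 5 ug/mL, which is a limit and not a number. Compound 2 (`CC(=O)OCC1=C2/C(=C\[C@@]3(C)CC[C@](O)(O3)[C@@](C)(O)C[C@@H]2O)OC1=O`) gives > 5 ug/mL, which is also a limit. Going by the values given here, the only measured step is a step that the two limits leave unreadable from compound 1 to compound 2, where acetyl takes the place of methyl on an oxygen on a saturated carbon. It gives no size to build on, and the data amount to the limit of > 5 ug/mL in this assay, at which 2 of the 2 values shown sit. Compound 3 (`COCC1=C2/C(=C\[C@@]3(C)CC[C@](O)(O3)[C@@](C)(O)C[C@@H]2OC(C)=O)OC1=O`) differs from compound 1 by acetyl in place of hydrogen on an oxygen on a saturated carbon. This is hydroxy to acetoxy, with acetyl in place of hydrogen on an oxygen on a saturated carbon. With no readable step to draw on, no change beyond the scatter is expected in this assay, and no direction can be favoured. The estimated step is a step that the limit leaves unreadable from compound 1 to compound 3. For compound 3 the expected value is 8 ug/mL, with an estimated range of 3 ug/mL to 30 ug/mL.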

Compound 3, half-maximal inhibitory concentration: > 5 ug/mL
Compound 3: a limit, no number (the forecaster's own chance of this, stated with the estimate: 60%); the middle value does not contradict the limit.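

In this assay compound 3 gives > 5 ug/mL, a limit and not a number, so no new step can be read between compound 1 and compound 3. The compounds shown leave open whether either acetyl change shifts the read-out at all, and by how much, as all the data stop at one point: the limit of > 5 ug/mL in this assay, at which 3 of the 3 values shown sit.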